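Swapping the pyridine for a dimethylpyrazole on the core

A few compounds are considered here, and "the series" means these few. Any claim that something is new, unique, unknown or untested is made for them only; others in the source may bear on it.

Measured so far:
Compound 1, `COc1ccc(OC)c(Sc2ccc3nnc(-c4ccccn4)n3n2)c1`: 496 nM
Compound 2, `COc1ccc(OC)c(Sc2ccc3nnc(-c4ccncc4)n3n2)c1`: 349 nM
Compound 3, `COc1ccc(OC)c(Sc2ccc3nnc(-c4ccsn4)n3n2)c1`: 91 nM

All three share one core and differ only in the aromatic ring attached to it. In an assay on isolated protein for inhibition of Leucine-rich repeat serine/threonine-protein kinase 2 (Homo sapiens), in the presence of a further agent that is not named here (on this read-out lower numbers stand for stronger inhibition and higher numbers for weaker inhibition), compound 2 gives 349 nM, the second highest of the three numbers; it sits close to compound 1, with a 1.4-fold lower number from compound 1 to compound 2 (0.15 log units; within the scatter), and further from compound 3, with a 3.8-fold lower number from compound 2 to compound 3 (0.58 log units; beyond the scatter).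

Compound 4, `COc1ccc(OC)c(Sc2ccc3nnc(-c4cn(C)nc4C)n3n2)c1`, is not yet measured. Compared with compound 2 it carries 1,3-dimethyl-1H-pyrazol-4-yl in place of pyridin-4-yl on an aromatic carbon.

Going by the values given here, two measured steps bear on this change. The exchange of one six-membered ring for another, a 1.4-fold lower number from compound 1 to compound 2 (0.15 log units; within the scatter), stayed within the scatter. The exchange of a six-membered ring for a five-membered one with two hetero atoms, a 3.8-fold lower number from compound 2 to compound 3 (0.58 log units; beyond the scatter) and a 5.5-fold lower number from compound 1 to compound 3 (0.74 log units; beyond the scatter), brought a modest gain both times. The incoming group in compound 4 is also a five-membered aromatic ring with two hetero atoms, but it differs from the ring in compound 3 in its atoms and carries two methyl groups, so the gain seen with compound 3 need not carry over.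

On that basis compound 4 is expected to give about 250 nM in this assay, within a range of 80 nM to 800 nM, which would mean an estimated step of a 1.4-fold lower number from compound 2 to compound 4 (0.14 log units; within the scatter).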

Compound 4, half-maximal inhibitory concentration: 323 nM
Estimate against measurement, compound 4: 1.3-fold (0.11 log units) below; measured number inside the range.
By their numbers in this assay, from the lowest: compound 3; then compounds 4, 2 and 1 (each within the scatter of the next).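

In this assay, the step of a 1.1-fold lower number from compound 2 to compound 4 (0.03 log units; within the scatter) and the step of a 1.5-fold lower number from compound 1 to compound 4 (0.19 log units; within the scatter) both stay within the scatter, so at this position the 1,3-dimethyl-1H-pyrazol-4-yl group cannot be told apart from either pyridine ring. The step of a 3.5-fold higher number from compound 3 to compound 4 (0.55 log units; beyond the scatter) shows that the gain seen with compound 3 does not extend to every five-membered aromatic ring with two hetero atoms, and compound 4 goes against any rule based on ring size alone. No measurement at hand explains what sets compound 3 apart from compounds 1, 2 and 4.

The compounds shown leave open whether the two methyl groups on compound 4 matter, since a plain 1H-pyrazol-4-yl group without them would be needed to separate the effect of the methyl groups from that of the pyrazole ring itself. They also leave open which feature of the 1,2-thiazol-3-yl group goes with the lower number, a question that a thiophene ring, or a 1,2-thiazol-3-yl group carrying a methyl group, could begin to address.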